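Dimethylamino in place of methyl on the shared core

A few compounds are considered here, and "the series" means these few. Any claim that something is new, unique, unknown or untested is made for them only; others in the source may bear on it.

In a functional assay on MOLT-4 cells (Homo sapiens) for inhibition (on this read-out higher numbers stand for weaker inhibition and lower numbers for stronger inhibition), compound 1 (`O=C1/C(=C/c2ccc(Br)cc2)CCc2ccccc21`) gives > 500000 nM as a limit of the assay. Going by these compounds, compound 2 (`Cc1ccc(/C=C2\CCc3ccccc3C2=O)cc1`) gives > 500000 nM and this too is only a limit, so its true position on the scale stays unknown. Both compounds therefore rest on the same limit (the limit of > 500000 nM in this assay, at which 2 of the 2 values shown sit). Going by the values given here, the only measured step is a step that the two limits leave unreadable from compound 1 to compound 2 and it offers no size to carry forward.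

Compound 3 (`CN(C)c1ccc(/C=C2\CCc3ccccc3C2=O)cc1`) carries dimethylamino in place of methyl on an aromatic carbon, para to a large group (dimethylamino in place of methyl on an aromatic carbon). Among the compounds with values here, no measured step shows any movement at this place, so the forecast is weakly grounded. With compound 2 at > 500000 nM as a limit and the sole anchor, only a modest shift toward stronger inhibition is expected, and another limit reading remains quite possible. The estimated change is an at least 2.5-fold lower number from compound 2 to compound 3 (0.39 log units; beyond the scatter) in this assay and its size is uncertain. For compound 3 the expected value is 200000 nM with an estimated range from 30000 nM to 500000 nM in this assay as the working forecast.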

Compound 3, half-maximal inhibitory concentration: 2110 nM
Beside the measured number, compound 3's estimate is 95-fold (1.98 log units) above it; measured number below the stated range.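

In this assay, the place on an aromatic carbon, para to a large group, turns out to be one where a single change can move the read-out: dimethylamino in place of methyl gives an at least 230-fold lower number from compound 2 to compound 3 (2.37 log units; beyond the scatter), and dimethylamino in place of bromo gives an at least 230-fold lower number from compound 1 to compound 3 (2.37 log units; beyond the scatter). Going by these compounds alone, these are the first readable steps, and compound 3 is the only one of the three compounds with a number rather than a limit. The step between compound 1 and compound 2 cannot be read, and the two new steps have only a lower bound on their size, as both starting compounds rest on the same limit: the limit of > 500000 nM in this assay, at which 2 of the 3 values shown sit.

Going by these compounds, whether the lower number needs dimethylamino itself stays open, since a simple amine, a pyrrolidine or a methoxy group at this place would separate the effect of that particular group from that of other groups carrying a heteroatom. With one readable value, the compounds shown give no trend across groups at this place, and they leave open what dimethylamino would do at any other carbon of the ring.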